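The source may report more compounds than this note shows. Statements on the series, on what has been measured and on what is new or still open speak of the compounds shown alone.

Compound 1 `Nc1sc2c(c1-c1nc3ccccc3s1)CCCC2` and compound 2 `Nc1sc2c(c1-c1nc3cc(Cl)ccc3s1)CCCC2` share one core; compound 2 carries chloro in place of hydrogen on an aromatic carbon. In an ADME assay on HepG2 cells (Homo sapiens) for cytotoxicity, read by MTT assay, with a stated time of 72 h (on this read-out lower numbers stand for higher toxicity in this test and higher numbers for lower toxicity in this test), compound 1 gives 163 ug/mL, and compound 2 gives 93.7 ug/mL, the step being a 1.7-fold lower number from compound 1 to compound 2 (0.24 log units; within the scatter). Compound 3 `Clc1ccc(/C=N/c2sc3c(c2-c2nc4ccccc4s2)CCCC3)cc1` differs from compound 1 in its core by a group of 9 heavy atoms (7 carbon, 1 nitrogen, 1 chlorine; one six-membered aromatic ring of carbon only) in place of one nitrogen atom, on an aromatic carbon; in this assay compound 3 gives 397 ug/mL, and the step is a 2.4-fold higher number from compound 1 to compound 3 (0.39 log units; beyond the scatter). Compound 4 `Clc1ccc(/C=N/c2sc3c(c2-c2nc4ccccc4s2)CCCC3)c(Cl)c1` has not yet been measured; it differs from compound 3 by chloro in place of hydrogen on an aromatic carbon. This is the same kind of change as from compound 1 to compound 2, though the place now is ortho to a large group and meta to a chloro group, whereas before it was part of a fused or bridged system of two rings, meta and para to a fused ring. The step is expected to be a 1.4-fold lower number from compound 3 to compound 4 (0.15 log units; within the scatter), because the same kind of change gave a 1.7-fold lower number from compound 1 to compound 2 (0.24 log units; within the scatter). Compound 4 is therefore estimated at 280 ug/mL, likely between 150 ug/mL and 520 ug/mL.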

Compound 4, half-maximal cytotoxic concentration: 384 ug/mL
Compound 4: the middle estimate sits 1.4-fold (0.14 log units) below what was measured, within the range that was stated.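

In this assay, putting chloro in place of hydrogen turns the 4-chlorophenyl of compound 3 into the 2,4-dichlorophenyl of compound 4, and the step is a 1.0-fold lower number from compound 3 to compound 4 (0.01 log units; within the scatter). Set beside the same change on the other core, the two steps agree as far as this test can tell: the same change on two cores in this assay, a 1.7-fold lower number (0.24 log units; within the scatter) from compound 1 to compound 2 and a 1.0-fold lower number (0.01 log units; within the scatter) from compound 3 to compound 4, 1.7-fold (0.23 log units) apart, within the scatter of two such steps. This shows that the change carried across these two cores without a step beyond the scatter, but it rests on one pair per core, with the chloro at a different place in each, and neither step is large enough to show a real effect of chloro.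

From the compounds shown here alone, what a methoxy group or a carboxylic acid would do in place of that same hydrogen stays open. So does whether the agreement would hold on a third core.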